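This account rests on a few compounds, and the source may have more. Where it says the series, first, only, none or still open, it means among the compounds named here.

Measured compounds:
compound 1 `CCc1ccc2nc(C(=O)Nc3c(F)cc(-c4cccc(F)c4)cc3F)c(C)c(O)c2c1` — 0.74%
compound 2 `Cc1c(C(=O)Nc2c(F)cc(-c3cccc(F)c3)cc2F)nc2ccc(F)cc2c1O` — -0.12%
compound 3 `Cc1c(C(=O)Nc2c(F)cc(-c3cccc(F)c3)cc2F)nc2ccc(C(F)(F)F)cc2c1O` — -0.33%

In a functional assay on Hep 3B2 cells (Homo sapiens) for antiproliferative activity, read by MTT assay, with a stated time of 24 h, tested at 0.01 ug/mL (a lower number here means a weaker effect, a higher number a stronger effect of the compound at the concentration tested), all three numbers sit close to zero. Compound 2 stands second highest of the three; the nearest number belongs to the pair a number 0.2 percentage points lower from compound 2 to compound 3 (within the scatter), the furthest to the pair a number 0.9 percentage points lower from compound 1 to compound 2 (within the scatter). The third step in the set, a number 1.1 percentage points lower from compound 1 to compound 3 (within the scatter), is likewise within the scatter. For the measured compounds named here, nothing so far moves the read-out.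

Compound 4 `Cc1c(C(=O)Nc2c(F)cc(-c3cccc(F)c3)cc2F)nc2ccc(F)cc2c1C(=O)O` is the next member. It differs from compound 2 as follows: carboxy in place of hydroxy on an aromatic carbon.

Going by the values given here, none of the measured steps touches this group: the three known steps all exchange ethyl, fluoro and trifluoromethyl against one another on a different aromatic carbon, and all three fall within the scatter. They therefore bear on the new step only indirectly, by showing that the series as a whole gives numbers near zero in this assay at the concentration tested. Among the compounds with values here, no measured compound carries a carboxy group, so the change itself is uncharted.

On that basis compound 4 is expected to give 0%, with a range from -5% to 5%. The step of a number 0.1 percentage points higher from compound 2 to compound 4 (within the scatter) is expected to stay within the scatter.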

Compound 4, a percentage reported as inhibition, at one concentration (the size of the read-out at that concentration, not a potency): -0.35%
Estimate against measurement, compound 4: 0.4 percentage points above; low and high end bracket the measured number.
By their numbers in this assay, from the lowest: compounds 4, 3, 2 and 1 (each within the scatter of the next).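

In this assay, for the compounds shown here, replacing hydroxy with carboxy on the aromatic carbon opposite the ring nitrogen gives a number 0.2 percentage points lower from compound 2 to compound 4 (within the scatter), the first reading on this position and the first change away from the aromatic carbon that carries ethyl, fluoro or trifluoromethyl. Changes at both places now leave the read-out within the scatter, and the numbers of all four compounds stay close to zero, so at this single concentration neither place separates one group from another. No measurement here offers an explanation for the unchanged read-out.

Because every number sits near zero, the data leave open whether hydroxy and carboxy would differ at a concentration where the series gives a clear effect, and whether either place matters for antiproliferative activity at all. Also open, on these data alone, is how a methyl ester, a primary amide or an amine would read on the carbon opposite the ring nitrogen, since the shared core has so far been seen there with hydroxy and carboxy only.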